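The source may hold more compounds than are shown below. What is called first, only, known or untested is meant among the compounds shown, and "the series" means these compounds.

Measured so far:
- compound 1, `OC[C@H]1O[C@@H](n2cnc3c(NCc4ccccc4Cl)ncnc32)[C@H](O)[C@@H]1O`. In an ADME assay on NIH3T3 cells (Mus musculus) for cytotoxicity, with a stated time of 72 h (on this read-out higher numbers stand for weaker inhibition and lower numbers for stronger inhibition), compound 1 gives only a limit, > 166000 nM.
- compound 2, `COc1ccccc1CNc1ncnc2c1ncn2[C@@H]1O[C@H](CO)[C@@H](O)[C@H]1O`. In this assay compound 2 gives 140000 nM.

Within the data shown here, compound 2 holds the only number in this assay so far; the other value is a limit. Among the measured compounds shown here, the single measured step, an at least 1.1-fold lower number from compound 1 to compound 2 (0.07 log units; that floor lies within the scatter), is the exchange of chloro for methoxy on the aromatic ring, and its floor lies inside the scatter, so it tells nothing about direction. The limit is described by the limit of > 166000 nM in this assay, at which 1 of the 2 values shown sits.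

Compound 3, `COc1cccc(CNc2ncnc3c2ncn3[C@@H]2O[C@H](CO)[C@@H](O)[C@H]2O)c1O`, is the next member. Relative to compound 2 the change is 2-hydroxy-3-methoxyphenyl in place of 2-methoxyphenyl on a saturated chain carbon bound to a nitrogen on an aromatic ring. For the measured compounds named here, no measured step touches a 2-hydroxy-3-methoxyphenyl group or any hydroxyl on the ring; the one step known, from chloro to methoxy, stayed within scatter. The expectation for compound 3 in this assay is therefore no movement beyond the scatter, a step of no change at the digits printed from compound 2 to compound 3 (within the scatter). Compound 3 is estimated at 140000 nM, with a range from 70000 nM to 300000 nM, and a real chance that only a limit is reported.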

Compound 3, half-maximal inhibitory concentration: > 166000 nM
Compound 3: no number, only a limit; the forecaster's own chance of this, stated with the estimate: 40%; middle value at least 1.1-fold (0.07 log units) away from the limit.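

In this assay, 2-hydroxy-3-methoxyphenyl in place of 2-methoxyphenyl on a saturated chain carbon bound to a nitrogen on an aromatic ring gives an at least 1.1-fold higher number from compound 2 to compound 3 (0.07 log units; that floor lies within the scatter), so only a floor is known and no direction can be read from this step. Among these compounds, the entering group carries a hydrogen-bond donor that the leaving group lacks, and this first change of that kind at the position produces no step that can be stated as beyond the scatter; the step between the two compounds that give only limits cannot be read. With three groups now tried at this position, the series sits mostly at the assay's limit: the limit of > 166000 nM in this assay, at which 2 of the 3 values shown sit.

Among the compounds shown here, whether any group at this position can bring the number clearly below that of compound 2 remains open, as compound 2 is the only compound with a number. An aminomethyl or carboxylic acid group on the phenyl ring, or a longer chain between the ring and the nitrogen, would test whether this position can move the read-out at all.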